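Changing the sulfonamide group of compound 2

The source may report more compounds than this note shows. Statements on the series, on what has been measured and on what is new or still open speak of the compounds shown alone.

In an ADME assay on microsomes from liver (Mus musculus, strain CD-1) for metabolic stability, read by LC-MS, tested at 2 uM (on this read-out higher numbers stand for a longer-lived compound and lower numbers for a shorter-lived compound), compound 1 (`CN(C)S(=O)(=O)c1ccccc1Nc1cc(-c2ccc3ccn(C)c3c2)c2nccnc2c1`) gives 0.233 h and compound 2 (`Cn1ccc2ccc(-c3cc(Nc4ccccc4S(=O)(=O)Nc4cncnc4)cc4nccnc34)cc21`) stands highest so far with 0.683 h on this short list. Compound 3 (`Cn1cc(CNS(=O)(=O)c2ccccc2Nc2cc(-c3ccc4ccn(C)c4c3)c3nccnc3c2)cn1`) carries (1-methyl-1H-pyrazol-4-yl)methyl in place of pyrimidin-5-yl on a sulfonamide nitrogen. Among the compounds with values here, the one measured step at that place was modest (a 2.9-fold higher number from compound 1 to compound 2 (0.47 log units; beyond the scatter)). It involved other groups, so it is only a rough guide. A step no larger than that one is expected, pointing slightly downward (a 1.5-fold lower number from compound 2 to compound 3 (0.18 log units; within the scatter)). Compound 3 is therefore estimated at 0.45 h (range 0.2 h to 1 h).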

Compound 3, half-life: 0.267 h
Compound 3: the middle estimate sits 1.7-fold (0.23 log units) above what was measured; the measured number falls inside the stated range.
By their numbers in this assay, from the lowest: compounds 1 and 3 (each within the scatter of the next); then compound 2.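

In this assay the group on a sulfonamide nitrogen can matter: (1-methyl-1H-pyrazol-4-yl)methyl in place of pyrimidin-5-yl gives a 2.6-fold lower number from compound 2 to compound 3 (0.41 log units; beyond the scatter) and so gives back the gain seen earlier. Against the dimethylamino compound, the same group gives a 1.1-fold higher number from compound 1 to compound 3 (0.06 log units; within the scatter) and leaves compound 2 alone at the top of these three. No measurement shown here accounts for this difference. Going by these compounds, whether the higher number needs pyrimidin-5-yl itself stays open, and a phenyl or pyridin-3-yl group on that nitrogen would help to answer this.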